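The source may hold more compounds than are shown below. What is called first, only, known or untested is meant among the compounds shown, and "the series" means these compounds.

Compound 1, `CCC(=O)Nc1ccc(-c2nc3cc(C(F)(F)F)ccc3[nH]2)cc1`: 100000 nM
Compound 2, `Cn1c(-c2ccc(NC(=O)CN3CCCCC3)cc2)nc2cc(C(F)(F)F)ccc21`: > 100000 nM, a limit of the assay rather than a number

Both compounds were tested in an ADME assay on BHK cells (Mesocricetus auratus) for cytotoxicity, read by MTT assay, with a stated time of 96 h; a lower number here means that less compound is tolerated, a higher number that more compound is tolerated. Compound 1 gives 100000 nM. For compound 2 the result is only a limit, > 100000 nM, so it stands at the limit of > 100000 nM in this assay, at which 1 of the 2 values shown sits, rather than at a measured number. Compound 3 `O=C(CN1CCCCC1)Nc1ccc(-c2nc3cc(C(F)(F)F)ccc3[nH]2)cc1` has not yet been measured. It differs from compound 2 in one place: hydrogen in place of methyl on an aromatic nitrogen. Within the data shown here, no step between two measured compounds is available here, so the size of this change has no measured precedent. Because compound 1 reached 100000 nM with hydrogen on that aromatic nitrogen, the step of a number no higher from compound 2 to compound 3 (the limit leaves the size open) is expected to stay within the usual scatter, in either direction. For compound 3 the estimate in this assay is 100000 nM, with a range from 40000 nM to 200000 nM, and a fair chance that only a limit is reported again.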

Compound 3, half-maximal cytotoxic concentration: 12000 nM
For compound 3 the middle estimate is 8.3-fold (0.92 log units) above the measured one; the whole stated range lies above it.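

In this assay, hydrogen in place of methyl on an aromatic nitrogen brings an at least 8.3-fold lower number from compound 2 to compound 3 (0.92 log units; beyond the scatter), which gives this change its first measured size and shows that this position matters when piperidin-1-yl is present. With hydrogen kept on that nitrogen, piperidin-1-yl in place of methyl on a saturated chain carbon bound to a carbonyl carbon brings an 8.3-fold lower number from compound 1 to compound 3 (0.92 log units; beyond the scatter), so the side chain matters as well. The true size of the step at the nitrogen stays open, since compound 2 stands at a limit of the assay and not at a number: the limit of > 100000 nM in this assay, at which 1 of the 3 values shown sits.

As far as these compounds go, it remains open whether an ethyl group on that aromatic nitrogen would act as methyl does here. From the compounds shown here alone, it is also open whether a morpholine ring or a dimethylamino group in place of piperidin-1-yl would give a similar step.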